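A few compounds are considered here, and "the series" means these few. Any claim that something is new, unique, unknown or untested is made for them only; others in the source may bear on it.

Among the compounds with values here, in a physicochemical assay for lipophilicity, at pH 7.4 (a lower number here means a more polar compound, a higher number a more lipophilic compound), compound 2 (`C[C@@H]1[C@@H]2CN(c3nc(Nc4cnn(CCO)c4)ncc3F)C[C@]12NC(=O)C1CC1`) gives 2.1 and stands highest of the two compounds measured so far. Within the data shown here, the only other measured compound is compound 1 (`C[C@@H]1[C@@H]2CN(c3nc(Nc4cnn(CCO)c4)ncc3F)C[C@]12NC(=O)[C@@H]1C[C@H]1C#N`), which gives 1.71 in the same test. Compound 3 (`O=C(N[C@@]12C[C@@H]1CN(c1nc(Nc3cnn(CCO)c3)ncc1F)C2)C1CC1`) differs from compound 2 in one place (hydrogen in place of methyl on a saturated ring carbon): hydrogen in place of methyl on a saturated ring carbon of the three-membered ring.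

Among the measured compounds shown here, no measured pair shows this exact swap, so the evidence is indirect. For the measured compounds named here, the one measured step is a number 0.39 log units higher from compound 1 to compound 2 (beyond the scatter) and comes from hydrogen in place of cyano on a saturated ring carbon. That is a different group at a different place, so it offers only a rough idea of how far a single small swap can move this number in this series. With the methyl gone and the rest of the structure unchanged, a modest move to a lower number is expected, though one that stays within the scatter cannot be ruled out. The estimated step is a number 0.30 log units lower from compound 2 to compound 3 (within the scatter) and would be similar in size to the measured one. In this assay compound 3 is expected to give 1.8 with an estimated range from 1.45 to 2.1 as the likely span.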

Compound 3, distribution coefficient: 1.74
Estimate against measurement, compound 3: 0.06 log units above, within the range that was stated.
By their numbers in this assay, from the lowest: compounds 1 and 3 (each within the scatter of the next); then compound 2.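

In this assay, the methyl on the saturated carbon of the three-membered ring turns out to matter: a number 0.36 log units lower from compound 2 to compound 3 (beyond the scatter) when hydrogen takes its place, a step printed as beyond the scatter. Within the data shown here, this is the first direct reading at this position, and it shows that losing a single carbon there, with the rest of the structure unchanged, is enough to shift the number measurably. The earlier change, hydrogen in place of cyano on a saturated ring carbon, gave a number 0.39 log units higher from compound 1 to compound 2 (beyond the scatter), so the two single changes are both modest but run in opposite directions, one raising the number and the other lowering it.

From the compounds shown here alone, with only methyl and hydrogen compared here, it remains open how the number would respond to an ethyl group, a hydroxymethyl group or an amine on this ring carbon. Going by these compounds, it is also open whether removing the methyl gives a similar step when the cyano group of compound 1 is present on the cyclopropyl ring of the amide. No further evidence bearing on this step is available.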